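The source may hold more compounds than are shown below. What is called first, only, known or untested is meant among the compounds shown, and "the series" means these compounds.

In a functional assay on A549 cells (Homo sapiens) for cytotoxicity, read by MTT assay, with a stated time of 72 h (a higher number here means a weaker inhibitor, a lower number a stronger inhibitor), compound 1 `CN(C)CCn1cnnc1-c1cc(Oc2ccc(NC(=O)N/N=C/c3cc(C(C)(C)C)cc(C(C)(C)C)c3O)cc2F)ccn1` gives 980 nM. For compound 2 `COc1cc(/C=N/NC(=O)Nc2ccc(Oc3ccnc(-c4nncn4CCN(C)C)c3)c(F)c2)cc(OC)c1OC` the result is only a limit, > 100000 nM, marking (the limit of > 100000 nM in this assay, at which 1 of the 2 values shown sits); compound 2 therefore stands at the weak end of the numbers in hand. Compound 3 `Cc1cc(/C=N/NC(=O)Nc2ccc(Oc3ccnc(-c4nncn4CCN(C)C)c3)c(F)c2)cc(C)c1O` is not yet measured; it carries 4-hydroxy-3,5-dimethylphenyl in place of 3,4,5-trimethoxyphenyl on a carbon with a double bond to nitrogen. Going by the values given here, no step between measured compounds is known here, so the size of the change cannot be read from the series; the entering group sits closer to what compound 1 carries, and a gain beyond the scatter is anticipated. Compound 3 is expected to give 6000 nM, between 1000 nM and 60000 nM. That estimate implies an expected step of an at least 16-fold lower number from compound 2 to compound 3 (1.22 log units; beyond the scatter).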

Compound 3, half-maximal inhibitory concentration: 1640 nM
Beside the measured number, compound 3's estimate is 3.7-fold (0.56 log units) above it; the measured number falls inside the stated range.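

In this assay, the group on a carbon with a double bond to nitrogen proves decisive: 4-hydroxy-3,5-dimethylphenyl in place of 3,4,5-trimethoxyphenyl gives an at least 60-fold lower number from compound 2 to compound 3 (1.78 log units; beyond the scatter). The true size of this step stays unknown, as the value of compound 2 is a limit: the limit of > 100000 nM in this assay, at which 1 of the 3 values shown sits.

Compound 3 gives 1640 nM and compound 1 gives 980 nM, so two different groups at this place both give measured numbers.

On these data alone, the change alters the hydroxyl and the methyl groups together, so their separate contributions remain open. As far as these compounds go, how an amine or a carboxylic acid in place of the hydroxyl would read is also open.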